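The compounds below may be only part of what the source reports. "The series", "measured", "known", "first", "only" and "open" are said of these compounds alone.

Working notes on the series. The shared core is carried by compound 1 `Cc1cccc(-n2nncc2CN2C(=O)C3(C(C#N)=C(N)Oc4c(N)cc5nc6ccccc6nc5c43)c3ccccc32)c1`, compound 2 `N#CC1=C(N)Oc2c(N)cc3nc4ccccc4nc3c2C12C(=O)N(Cc1cnnn1-c1cccc(C(F)(F)F)c1)c1ccccc12` and compound 3 `Cc1cc(C)cc(-n2nncc2CN2C(=O)C3(C(C#N)=C(N)Oc4c(N)cc5nc6ccccc6nc5c43)c3ccccc32)c1`, which differ only in the aryl group on the triazole nitrogen. In a functional assay on HCT-116 cells (Homo sapiens) for antiproliferative activity, read by MTT assay, with a stated time of 48 h (a lower number here means a stronger inhibitor, a higher number a weaker inhibitor), compound 1 gives > 50000 nM, which is a limit of the assay and not a number. Compound 2 gives 18900 nM in this assay. Compound 3 gives > 50000 nM, again a limit of the assay rather than a number, so compound 3 stands at the limit of > 50000 nM in this assay, at which 2 of the 3 values shown sit.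

Among the measured compounds shown here, two measured steps bear on the next change. Going an at least 2.6-fold lower number from compound 1 to compound 2 (0.42 log units; beyond the scatter). Going an at least 2.6-fold higher number from compound 2 to compound 3 (0.42 log units; beyond the scatter). A 3-(trifluoromethyl)phenyl thus reads better than either methyl-bearing phenyl, while the step that the two limits leave unreadable from compound 1 to compound 3.

Compound 4 `N#CC1=C(N)Oc2c(N)cc3nc4ccccc4nc3c2C12C(=O)N(Cc1cnnn1-c1c(Cl)cc(Cl)cc1Cl)c1ccccc12` carries 2,4,6-trichlorophenyl in place of 3,5-dimethylphenyl on an aromatic nitrogen. Given that the only numeric value sits with the trifluoromethyl-bearing compound 2 at 18900 nM, a step in this assay toward a lower number is expected for compound 4, of at least modest size. Compound 4 is estimated at 22000 nM, with a range of 8000 nM to 60000 nM. That estimate implies an expected step of an at least 2.2-fold lower number from compound 3 to compound 4 (0.35 log units; beyond the scatter).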

Compound 4, half-maximal inhibitory concentration: 12100 nM
The estimate for compound 4 lay 1.8-fold (0.26 log units) above the measured number, and the stated range covers the measured number.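

On the aromatic nitrogen, 2,4,6-trichlorophenyl gives a second measurable value in this assay and shows that a number here is not confined to 3-(trifluoromethyl)phenyl. Compared with the methyl-bearing aryl groups, the change gives an at least 4.1-fold lower number from compound 3 to compound 4 (0.61 log units; beyond the scatter) and an at least 4.1-fold lower number from compound 1 to compound 4 (0.61 log units; beyond the scatter) while the comparison with the trifluoromethyl-bearing aryl group gives a 1.6-fold lower number from compound 2 to compound 4 (0.19 log units; within the scatter) and so does not separate these two groups. Among the four compounds, only the methyl-bearing compound 1 and compound 3 remain at a limit of the assay and not a number: the limit of > 50000 nM in this assay, at which 2 of the 4 values shown sit.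

On these data alone, it stays open whether the number of chlorine atoms or their placing on the phenyl ring matters. Also open, as far as these compounds go, is how a phenyl bearing a single chlorine, a methoxy group or a carboxylic acid would read in this assay at this position.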